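A Shorter Link Between Core and Phenyl Ring

A few compounds are considered here, and "the series" means these few. Any claim that something is new, unique, unknown or untested is made for them only; others in the source may bear on it.

Measured compounds:
Compound 1: `CCCCNc1nc(N)nc(C)c1CCCc1ccccc1`, 749 nM
Compound 2: `CCCCNc1nc(N)nc(C)c1CCCN(CC)CC`, 254 nM
Compound 3: `CCCCNc1nc(N)nc(C)c1CCCn1cccn1`, 1050 nM

In an assay on HEK293 cells for agonist activity at Toll-like receptor 8 (Homo sapiens), read by spectrophotometry (on this read-out lower numbers stand for an effect already at smaller amounts and higher numbers for an effect only at larger amounts of compound), compound 1 gives 749 nM and stands second highest of the three numbers. Compound 2 gives 254 nM, giving a 2.9-fold lower number from compound 1 to compound 2 (0.47 log units; beyond the scatter), while compound 3 gives 1050 nM, giving a 1.4-fold higher number from compound 1 to compound 3 (0.15 log units; within the scatter). Compound 4 `CCCCNc1nc(N)nc(C)c1CCc1ccccc1` differs from compound 1 by phenyl in place of benzyl on a saturated chain carbon, two bonds along the chain from an aromatic carbon. Among the measured compounds shown here, each measured step swaps the group at the far end of the chain and leaves its length unchanged, so no step bears directly on this change; the measured spread is modest at most. A step within the scatter is therefore expected, with no clear direction: a 1.1-fold higher number from compound 1 to compound 4 (0.03 log units; within the scatter). Compound 4 is estimated at 800 nM, with a range from 300 nM to 2500 nM.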

Compound 4, half-maximal effective concentration: 1190 nM
For compound 4 the middle estimate is 1.5-fold (0.17 log units) below the measured one; measured number inside the range.
By their numbers in this assay, from the lowest: compound 2; then compounds 1, 3 and 4 (each within the scatter of the next).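

In this assay, phenyl in place of benzyl removes one chain carbon and gives a 1.6-fold higher number from compound 1 to compound 4 (0.20 log units; within the scatter) and so leaves no readable effect of the shorter link. Compound 4 also gives a 1.1-fold higher number from compound 3 to compound 4 (0.05 log units; within the scatter) and a 4.7-fold higher number from compound 2 to compound 4 (0.67 log units; beyond the scatter) and so, like compound 1 and compound 3, stays apart from the diethylamino compound. Nothing measured here gives a reason for these steps. On these data alone, whether diethylamino would hold its lower number on the shorter chain remains open. So does the outcome for a longer chain ending in phenyl, or for a chain ending in a primary amine or a carboxylic acid.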